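The source may report more compounds than this note shows. Statements on the series, on what has been measured and on what is new or still open speak of the compounds shown alone.

Of the compounds shown here, two with a shared core have been tested in a functional assay on the whole organism with Rattus norvegicus as the target, at a dose of 3 mg/kg by the oral route; on this read-out lower numbers stand for a weaker effect and higher numbers for a stronger effect at the one dose given. Compound 1, `Nc1ccc(-c2cc(Cl)cc(C(=O)Nc3nn[nH]n3)n2)cc1`, gives 100%. Compound 2, `COc1ccc(-c2cccc(C(=O)Nc3nn[nH]n3)n2)cc1`, gives 36%, the lowest of the two numbers, well below the number for compound 1. Compound 3, `Nc1ccc(-c2cccc(C(=O)Nc3nn[nH]n3)n2)cc1`, is not yet measured; it differs from compound 2 by amino in place of methoxy on an aromatic carbon. A rise is expected, because compound 1, which also carries an amino group, gives 100%. The step of a number 29 percentage points higher from compound 2 to compound 3 (beyond the scatter) is expected to be beyond the scatter. Compound 3 is estimated at 65%, between 40% and 90%.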

Compound 3, a percentage reported as inhibition, in the whole organism at one dose (the size of the read-out at that dose, not a potency): 81%
For compound 3 the middle estimate is 16 percentage points below the measured one, within the range that was stated.
By their numbers in this assay, from the lowest: compound 2; then compound 3; then compound 1.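

In this assay, amino in place of methoxy on the aromatic carbon para to a large group gives a number 45 percentage points higher from compound 2 to compound 3 (beyond the scatter), so this position responds strongly to the change while the rest of the molecule stays the same. The chloro group also counts, though less: hydrogen in its place gives a number 19 percentage points lower from compound 1 to compound 3 (beyond the scatter). Nothing available here explains either step. As far as these compounds go, whether a hydroxyl or dimethylamino group at the para position would match amino remains open, as does the effect of chloro alongside methoxy.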